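Swapping a Urea for an Aryl Amide: Cytotoxicity Outlook

The source may hold more compounds than are shown below. What is called first, only, known or untested is meant among the compounds shown, and "the series" means these compounds.

Three measured compounds and one unmeasured compound share a common core. Compound 1 `CCN(CC)c1cc2[nH]c(C3CCCCC3)nc2cc1NC(=O)c1cnccn1` carries a diethylamino group and a pyrazine amide. In an ADME assay on Vero cells (Chlorocebus sabaeus) for cytotoxicity, read by resazurin assay, with a stated time of 3 days (a lower number here means a stronger inhibitor, a higher number a weaker inhibitor), compound 1 gives > 100 ug/mL, which is a limit of the assay rather than a number. Compound 2 `CCN(CC)c1cc2[nH]c(C3CCCCC3)nc2cc1NC(=O)c1ccc(N(C)C)cc1` in this assay gives "not determined" (no result reported). Compound 3 `CCCNC(=O)Nc1cc2nc(C3CCCCC3)[nH]c2cc1N1CCCC1`, with a pyrrolidine and a propyl urea, in this assay gives > 100 ug/mL, again a limit rather than a number. Compound 3 therefore stands where every compound with a result stands: two of the three entries sit at the limit and the third is missing, so no number sets compound 3 apart from compound 1. the limit of > 100 ug/mL in this assay, at which 2 of the 3 values shown sit, sums up this shared position.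

Compound 4 `COc1ccc(C(=O)Nc2cc3nc(C4CCCCC4)[nH]c3cc2N2CCCC2)cc1` has not yet been measured. It differs from compound 3 in one place: 4-methoxyphenyl in place of propylamino on a carbonyl carbon. Among the measured compounds shown here, no step between two measured compounds exists to calibrate this change. For the measured compounds named here, with the only available values sitting at the limit, the expected step is a number no higher from compound 3 to compound 4 (the limit leaves the size open), that is, nothing beyond the usual scatter. Compound 4 is accordingly expected to give about 100 ug/mL in this assay, within a range from 40 ug/mL to 250 ug/mL.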

Compound 4, half-maximal inhibitory concentration: > 100 ug/mL
Compound 4 gave a limit, no number; the forecaster's own chance of this, stated with the estimate: 70%; the middle value lies on the limit itself.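

Among the compounds shown here, compound 3 and compound 4 both rest on a limit rather than a number in this assay, and no step between them can be read. What they share is this: the limit of > 100 ug/mL in this assay, at which 3 of the 4 values shown sit. The compounds shown leave open whether 4-methoxyphenyl in place of propylamino on a carbonyl carbon changes cytotoxicity at all, and at what concentration any of them would harm the cells.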